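The compounds below may be only part of what the source reports. "The series", "measured", "known", "first", "only" and "open" are said of these compounds alone.

Working notes on the series, read-out an ADME assay for permeability, using PAMPA, with a stated time of 30 min, at pH 7.4; a lower number here means that the compound crosses the layer more slowly, a higher number that the compound crosses the layer faster. Compound 1 `COc1cccc(CNCCCNc2ccnc3cc(-c4ccc(F)cc4)ccc23)c1O` gives 237 10^-6 cm/s, compound 2 `COc1cccc(CNCCCNc2ccnc3cc(-c4ccc(C(C)(C)C)cc4)ccc23)c1O` gives 237 10^-6 cm/s and compound 3 `COc1cccc(Oc2ccc3c(NCCCNCc4cccc(OC)c4O)ccnc3c2)c1` gives 317 10^-6 cm/s. All three values lie within the scatter of one another, so compound 3 cannot be separated from the other two. The measured steps leading to it are a 1.3-fold higher number from compound 1 to compound 3 (0.13 log units; within the scatter) and a 1.3-fold higher number from compound 2 to compound 3 (0.13 log units; within the scatter). Tert-butyl in place of fluoro gives no change at the digits printed from compound 1 to compound 2 (within the scatter).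

Compound 4 `COc1cccc(CNCCCNc2ccnc3cc(CCC(C)C)ccc23)c1O` is the next case: isopentyl in place of 3-methoxyphenoxy on an aromatic carbon, with the count (isopentyl in place of 3-methoxyphenoxy on an aromatic carbon). Among the measured compounds shown here, no measured compound carries a group without a ring at this place, so the step goes beyond what the data cover directly. The closest evidence is the change at the same place seen in a 1.3-fold higher number from compound 1 to compound 3 (0.13 log units; within the scatter) and a 1.3-fold higher number from compound 2 to compound 3 (0.13 log units; within the scatter), both small. On that evidence, no step beyond the scatter is expected in this assay, and no direction can be called. The expected change is a 1.2-fold lower number from compound 3 to compound 4 (0.09 log units; within the scatter). For compound 4 the estimated value is 260 10^-6 cm/s, with an expected range of 130 10^-6 cm/s to 480 10^-6 cm/s.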

Compound 4, apparent permeability: 23 10^-6 cm/s
Beside the measured number, compound 4's estimate is 11-fold (1.05 log units) above it; measured number below the stated range.
By their numbers in this assay, from the lowest: compound 4; then compounds 1, 2 and 3 (each within the scatter of the next).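

In this assay this position is not silent, as compounds 1, 2 and 3 alone suggested: isopentyl in place of 3-methoxyphenoxy gives a 14-fold lower number from compound 3 to compound 4 (1.14 log units; beyond the scatter) and isopentyl in place of 4-(tert-butyl)phenyl gives a 10-fold lower number from compound 2 to compound 4 (1.01 log units; beyond the scatter) and isopentyl in place of 4-fluorophenyl gives (a 10-fold lower number from compound 1 to compound 4 (1.01 log units; beyond the scatter)). The three groups that carry a six-membered aromatic ring of carbon only remain within the scatter of one another, so among the compounds shown the only step beyond the scatter at this place separates them from compound 4, whose group has no ring. Nothing available bears on the reason for this step.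

With isopentyl the only group without a ring, the compounds shown cannot separate the loss of the aromatic ring from other differences between the leaving and entering groups, such as size or the shape of the chain. Cyclohexyl, a saturated ring, and benzyl, a ring held away from the core, would test this at the same place, and a longer chain would show whether the low number holds for open chains generally.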